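Working notes: from compound 1 toward compound 4 in cell cytotoxicity

The compounds below may be only part of what the source reports. "The series", "measured", "known", "first", "only" and "open" are said of these compounds alone.

The series shares one core, as in compound 1 `CC(C)c1cccc(NC(=O)CCc2cccc3c2B(O)OC3)c1`. In an ADME assay on WI-38 cells (Homo sapiens) for cytotoxicity, read by MTT assay, with a stated time of 72 h (a lower number here means a stronger inhibitor, a higher number a weaker inhibitor), compound 1 gives 22000 nM, the only numerical result among the three compounds measured. Compound 2 `COc1ccc(NC(=O)CCc2cccc3c2B(O)OC3)cc1OC` reaches only the limit of the assay, > 100000 nM. Compound 3 `O=C(CCc1cccc2c1B(O)OC2)Nc1ccc2ccccc2c1` likewise sits at the limit, > 100000 nM. Compound 1 therefore stands alone with a measurable value, the other two resting at the limit (the limit of > 100000 nM in this assay, at which 2 of the 3 values shown sit). Among the compounds with values here, no pair of measured compounds differs in one place, so no measured step guides the next one. Compound 4 `O=C(CCc1cccc2c1B(O)OC2)Nc1cccc(-c2ccc(C(F)(F)F)cc2)c1` is not yet measured; it differs from compound 1 by 4-(trifluoromethyl)phenyl in place of isopropyl on an aromatic carbon. Without a comparable measured step, a modest step is expected a 1.5-fold lower number from compound 1 to compound 4 (0.17 log units; within the scatter), toward a lower number. For compound 4 the expected value is 15000 nM, within 4000 nM to 60000 nM.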

Compound 4, half-maximal inhibitory concentration: 26000 nM
For compound 4 the middle estimate is 1.7-fold (0.24 log units) below the measured one; measured number inside the range.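

In this assay, 4-(trifluoromethyl)phenyl in place of isopropyl gives a 1.2-fold higher number from compound 1 to compound 4 (0.07 log units; within the scatter). This aromatic carbon, meta to a large group, therefore carries the larger group with its added aromatic ring without a readable shift in the number, which gives the series its first single-place comparison. Nothing measured here accounts for this outcome.

On these data alone, whether an amine or a carboxylic acid on this aromatic carbon would shift the number beyond the scatter remains open. As far as these compounds go, the effect of a longer chain at this place is equally open.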